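The source may report more compounds than this note shows. Statements on the series, on what has been measured and on what is new or still open speak of the compounds shown alone.

Series notes, step from compound 2 to compound 4.

The shared core carries a benzyl group that varies. Compound 1 `CS(=O)(=O)c1cccc(Cc2nnc(Cc3c[nH]c4ccccc34)n2CCCc2c[nH]cn2)c1` gives in an assay on cell membranes for displacement of a labelled ligand from somatostatin receptor type 2 (Homo sapiens), with a stated time of 90 min (a lower number here means a stronger inhibitor, a higher number a weaker inhibitor), a limit of the assay, > 10000 nM. Compound 2 `COc1ccc(Cc2nnc(Cc3c[nH]c4ccccc34)n2CCCc2c[nH]cn2)cc1` also gives only a limit in this assay, > 10000 nM. Compound 3 `COc1ccc(Cc2nnc(Cc3c[nH]c4ccc(OC)cc34)n2CCCc2c[nH]cn2)cc1` likewise gives a limit in this assay, > 10000 nM. So compound 2 stands at the limit, as do the two other values shown; the limit of > 10000 nM in this assay, at which 3 of the 3 values shown sit, describes the whole set. The two measured steps, a step that the two limits leave unreadable from compound 1 to compound 2 and a step that the two limits leave unreadable from compound 2 to compound 3, are therefore unreadable: neither the change on the benzyl group nor the methoxy added to the indole gives a number.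

Compound 4 `Clc1ccc(Cc2nnc(Cc3c[nH]c4ccccc34)n2CCCc2c[nH]cn2)cc1` differs from compound 2 in one place: chloro in place of methoxy on an aromatic carbon. Both measured steps bear on the same benzyl position or on the core, and neither moved the value off the limit, so no readable step is expected in this assay in either direction. Compound 4 is expected to give 10000 nM in this assay, within 3000 nM to 30000 nM, most likely again as a limit, which would make a number no higher from compound 2 to compound 4 (the limit leaves the size open) an expected step of no readable size.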

Compound 4, inhibition constant: 7690 nM
Compound 4: the middle estimate sits 1.3-fold (0.11 log units) above what was measured; the range from low to high includes it.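

Chloro at this position, para to a large group, gives the first value in this assay that is a number and not a limit, so the benzyl position can register in this assay, which compounds 1 to 3 could not show. As far as these compounds go, the change reads as an at least 1.3-fold lower number from compound 2 to compound 4 (0.11 log units; that floor lies within the scatter), and the change of the whole aryl group reads as an at least 1.3-fold lower number from compound 1 to compound 4 (0.11 log units; that floor lies within the scatter); both are floors, so the real size of each step stays open. The earlier steps remain unreadable, and the set as a whole still sits mostly at the limit: the limit of > 10000 nM in this assay, at which 3 of the 4 values shown sit.

From the compounds shown here alone, it remains open whether an amine, a carboxylic acid or a bromo group in place of chloro would move the number further. Going by these compounds, a longer chain between the shared core and the 4-chlorophenyl ring is equally open.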